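The source may report more compounds than this note shows. Statements on the series, on what has been measured and on what is new or still open speak of the compounds shown alone.

Measured compounds:
- compound 1, `CCOc1cc(NC(=O)C2(NC(=O)c3ccc4c(C5CCCC5)c(-c5ncc(Cl)cn5)n(C)c4c3)CCC2)ccc1/C=C/C(=O)OCOP(=O)(O)OC(C)(C)C`, in an ADME assay (liver) for pharmacokinetics, with Liver microsome (Rattus norvegicus) as the target, using microsomes (on this read-out higher numbers stand for a longer-lived compound and lower numbers for a shorter-lived compound), compound 1 gives 0.133 h
- compound 2, `CCOc1cc(NC(=O)C2(NC(=O)c3ccc4c(C5CCCC5)c(-c5ncc(Cl)cn5)n(C)c4c3)CCC2)ccc1/C=C/C(=O)OCc1ccccc1`, compound 2 gives 2.17 h
- compound 3, `CCOc1cc(NC(=O)C2(NC(=O)c3ccc4c(C5CCCC5)c(-c5ncc(Cl)cn5)n(C)c4c3)CCC2)ccc1/C=C/C(=O)OCCOc1ccccc1`, compound 3 gives 16.5 h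

All three share one core and differ only in the group on a saturated chain carbon bound to an oxygen next to a carbonyl group. Compound 3 has the highest number of the three in this assay: the step of a 7.6-fold higher number from compound 2 to compound 3 (0.88 log units; beyond the scatter) and the step of a 120-fold higher number from compound 1 to compound 3 (2.09 log units; beyond the scatter) both lie beyond the scatter, so compound 3 is the longest-lived compound here.

Compound 4, `CCCN(C)C(=O)COC(=O)/C=C/c1ccc(NC(=O)C2(NC(=O)c3ccc4c(C5CCCC5)c(-c5ncc(Cl)cn5)n(C)c4c3)CCC2)cc1OCC`, has not been measured. Its change from compound 3 is methyl(propyl)carbamoyl in place of phenoxymethyl on a saturated chain carbon bound to an oxygen next to a carbonyl group. Every measured step sits at this same place, and each of them was large: a 16-fold higher number from compound 1 to compound 2 (1.21 log units; beyond the scatter), a 120-fold higher number from compound 1 to compound 3 (2.09 log units; beyond the scatter) and a 7.6-fold higher number from compound 2 to compound 3 (0.88 log units; beyond the scatter). Among the compounds with values here, none of them, however, swaps a ring-bearing group for a chain ending in a carbamoyl group, so no measured step bears directly on this change. What the steps do show is that this position moves the read-out strongly in either direction, so a step beyond the scatter is expected, with the direction uncertain. Compound 4 is therefore expected to come in lower than compound 3, at 5 h, within a wide range from 1 h to 25 h, which is the step of a 3.3-fold lower number from compound 3 to compound 4 (0.52 log units; beyond the scatter).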

Compound 4, half-life: 0.317 h
Beside the measured number, compound 4's estimate is 16-fold (1.20 log units) above it; the whole stated range lies above it.
By their numbers in this assay, from the lowest: compound 1; then compound 4; then compound 2; then compound 3.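

In this assay, the change from phenoxymethyl to methyl(propyl)carbamoyl gives a 52-fold lower number from compound 3 to compound 4 (1.72 log units; beyond the scatter), so a group of similar size at this position can still shift the half-life strongly downward. The new compound also falls under the benzyl ester, with a 6.8-fold lower number from compound 2 to compound 4 (0.84 log units; beyond the scatter), yet it remains above the phosphate-bearing group, with a 2.4-fold higher number from compound 1 to compound 4 (0.38 log units; beyond the scatter), which shows that the two groups without a ring do not give the same number. Among these four compounds, both ring-bearing groups now give longer half-lives than both groups without a ring, with no compound going against this order, although nothing shown here explains that order or the size of these gaps.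

The compounds shown change the ring and the carbamoyl group together, so they leave open which of the two accounts for the drop from compound 3 to compound 4. A phenylcarbamoyl group, which keeps both, or a plain butyl chain, which has neither, at this same place would help to separate the two.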